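Lengthening the methoxy group of compound 3 to ethoxy

A few compounds are considered here, and "the series" means these few. Any claim that something is new, unique, unknown or untested is made for them only; others in the source may bear on it.

In a functional assay on MOLT-4 cells (Homo sapiens) for antiproliferative activity, with a stated time of 48 h (a lower number here means a stronger inhibitor, a higher number a weaker inhibitor), compound 1 (`C=C(Br)C(=O)Nc1ccc(/C=C/C(=O)c2ccc(Br)cc2)cc1`) gives 680 nM, compound 2 (`C=C(Br)C(=O)Nc1ccc(/C=C/C(=O)c2ccc(I)cc2)cc1`) gives 2800 nM and compound 3 (`C=C(Br)C(=O)Nc1ccc(/C=C/C(=O)c2ccc(OC)cc2)cc1`) gives 1300 nM. Compound 3 thus stands level with compound 1 within the scatter, and it shows a 2.2-fold lower number from compound 2 to compound 3 (0.33 log units; beyond the scatter). Compound 4 (`C=C(Br)C(=O)Nc1ccc(/C=C/C(=O)c2ccc(OCC)cc2)cc1`) differs from compound 3 by methyl in place of hydrogen on a saturated chain carbon bound to an oxygen on an aromatic ring, which turns methoxy into ethoxy. Within the data shown here, no measured step makes this change. The nearest evidence is exchange of the whole group on the aromatic carbon, which gave a 1.9-fold higher number from compound 1 to compound 3 (0.28 log units; within the scatter) and, as the largest step, a 4.1-fold higher number from compound 1 to compound 2 (0.61 log units; beyond the scatter). Only a small change of uncertain direction is therefore expected, and the estimated step is a 1.2-fold higher number from compound 3 to compound 4 (0.06 log units; within the scatter). The expected value for compound 4 is 1500 nM, estimated to lie between 650 nM and 3400 nM.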

Compound 4, half-maximal inhibitory concentration: 610 nM
Beside the measured number, compound 4's estimate is 2.5-fold (0.39 log units) above it; measured number outside the range, below it.
By their numbers in this assay, from the lowest: compounds 4, 1 and 3 (each within the scatter of the next, the first and the last beyond it); then compound 2.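

Adding one methyl to the methoxy group, with the oxygen kept on the aromatic ring, gives a 2.1-fold lower number from compound 3 to compound 4 (0.33 log units; beyond the scatter) for this small change, so the saturated chain carbon bound to that oxygen is not indifferent to substitution. Ethoxy stands level with bromo, at a 1.1-fold lower number from compound 1 to compound 4 (0.05 log units; within the scatter) in this comparison, and it clearly outperforms iodo, at a 4.6-fold lower number from compound 2 to compound 4 (0.66 log units; beyond the scatter) in the series. No evidence is available to explain these steps. The compounds shown leave open whether a longer chain such as propoxy would lower the number further. They also do not show how a branched isopropoxy group would behave here.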